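Compound 3: longer hydroxyalkyl chain on the triazole

A few compounds are considered here, and "the series" means these few. Any claim that something is new, unique, unknown or untested is made for them only; others in the source may bear on it.

In a functional assay on K562 cells (Homo sapiens) for inhibition, read by MTT assay, with a stated time of 72 h (on this read-out lower numbers stand for stronger inhibition and higher numbers for weaker inhibition), compound 1 `Cc1ccc(-n2cc(-c3ccc(C)c(C(F)(F)F)c3)nn2)cc1Nc1nccc(-c2cccnc2)n1` reads > 30000 nM, which is a limit of the assay and not a number. Among the measured compounds shown here, compound 2 `Cc1ccc(-n2cc(C(C)O)nn2)cc1Nc1nccc(-c2cccnc2)n1` gives 15300 nM, the only true number so far, so it cannot yet be ranked against a second measured value.

Compound 3 `Cc1ccc(-n2cc(CCCCO)nn2)cc1Nc1nccc(-c2cccnc2)n1` carries 4-hydroxybutyl in place of 1-hydroxyethyl on an aromatic carbon of the five-membered aromatic ring with 3 nitrogen (4-hydroxybutyl in place of 1-hydroxyethyl on an aromatic carbon). The rest of the molecule stays as in compound 2.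

For the measured compounds named here, only one measured step bears on this change: an at least 1.9-fold lower number from compound 1 to compound 2 (0.29 log units; that floor lies within the scatter). It swaps a much larger group, stays within the scatter and rests on (the limit of > 30000 nM in this assay, at which 1 of the 2 values shown sits). Going by the values given here, no measured step yet compares two hydroxyalkyl chains, so the expectation is anchored on compound 2 at 15300 nM.

The expected change is a 1.0-fold lower number from compound 2 to compound 3 (0.01 log units; within the scatter), and no step beyond the scatter is expected in this assay. For compound 3 the estimated value is 15000 nM, with an expected range from 6000 nM to 30000 nM.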

Compound 3, half-maximal inhibitory concentration: 11200 nM
Estimate against measurement, compound 3: 1.3-fold (0.13 log units) above; the range from low to high includes it.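

Exchanging 1-hydroxyethyl for 4-hydroxybutyl on this aromatic carbon of the triazole gives a 1.4-fold lower number from compound 2 to compound 3 (0.14 log units; within the scatter) in this assay, so the two hydroxyalkyl chains cannot be told apart here, and chain length across this pair has no readable effect on the number. Set against the 4-methyl-3-(trifluoromethyl)phenyl group of compound 1, the hydroxyalkyl series now shows its first step beyond the scatter: an at least 2.6-fold lower number from compound 1 to compound 3 (0.42 log units; beyond the scatter). That step is only a floor, since the value of compound 1 is a limit of the assay and not a number: the limit of > 30000 nM in this assay, at which 1 of the 3 values shown sits.

Going by these compounds, whether any group at this position can bring the number well below that of compound 2 and compound 3 stays open, for instance a terminal amine, a carboxylic acid or a longer chain. Among the compounds shown here, a plain butyl chain would show whether the hydroxyl group matters at all, since both readable values so far come from chains that carry it.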